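Side-chain step from compound 3 to compound 4

This account rests on a few compounds, and the source may have more. Where it says the series, first, only, none or still open, it means among the compounds named here.

In a functional assay on MCF7 cells (Homo sapiens) for cytotoxicity, read by MTT assay, with a stated time of 72 h (on this read-out lower numbers stand for stronger inhibition and higher numbers for weaker inhibition), compound 1 `O=C1c2c[n+]([O-])c3ccccc3c2C(=O)c2c1c1ccccc1n2Cc1cn([C@@H]2C[C@H](O)[C@@H](CO)O2)nn1` gives 110 nM, compound 2 `CC1(C)OCC(Cn2cc(Cn3c4c(c5ccccc53)C(=O)c3c[n+]([O-])c5ccccc5c3C4=O)nn2)O1` gives 290 nM and compound 3 `O=C1c2c[n+]([O-])c3ccccc3c2C(=O)c2c1c1ccccc1n2Cc1cn(CC(O)CO)nn1` gives 1110 nM, the highest number of the three. Compound 4 `CC1(C)O[C@@H](CO)[C@H](Cn2cc(Cn3c4c(c5ccccc53)C(=O)c3c[n+]([O-])c5ccccc5c3C4=O)nn2)O1` alters the open side chain of compound 3: 5-(hydroxymethyl)-2,2-dimethyl-1,3-dioxolan-4-yl in place of 1,2-dihydroxyethyl on a saturated chain carbon bound to an aromatic nitrogen. The entering group keeps the 2,2-dimethyl-1,3-dioxolane ring of compound 2 and adds a hydroxymethyl, a group also present in compound 1. Within the data shown here, two measured steps bear on this, both beyond the scatter: a 3.8-fold higher number from compound 2 to compound 3 (0.58 log units; beyond the scatter) and a 10-fold higher number from compound 1 to compound 3 (1.00 log units; beyond the scatter). Read in reverse, they point to a lower number, so a drop of modest size is expected, a 4.3-fold lower number from compound 3 to compound 4 (0.63 log units; beyond the scatter). The estimate for compound 4 is 260 nM, with an expected range of 80 nM to 800 nM.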

Compound 4, half-maximal inhibitory concentration: 690 nM
For compound 4 the middle estimate is 2.7-fold (0.42 log units) below the measured one, within the range that was stated.
By their numbers in this assay, from the lowest: compound 1; then compound 2; then compounds 4 and 3 (each within the scatter of the next).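

Placing 5-(hydroxymethyl)-2,2-dimethyl-1,3-dioxolan-4-yl on this saturated chain carbon gives no clear change from 1,2-dihydroxyethyl (a 1.6-fold lower number from compound 3 to compound 4 (0.21 log units; within the scatter)). The hydroxymethyl added to the dioxolane ring goes with a weaker result (a 2.4-fold higher number from compound 2 to compound 4 (0.38 log units; beyond the scatter)), and a hydroxymethyl alone does not reproduce the oxolane side chain (a 6.3-fold higher number from compound 1 to compound 4 (0.80 log units; beyond the scatter)). No supporting data explain these differences.

From the compounds shown here alone, whether the two defined stereocentres of the entering group affect the result remains open. So does the effect of an amine or a carboxylic acid in place of this hydroxymethyl.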